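From 2-methylprop-1-en-1-yl to 3-methylbut-1-en-1-yl on the carbonyl

The compounds below may be only part of what the source reports. "The series", "measured", "known", "first", "only" and "open" are said of these compounds alone.

In a functional assay on A549 cells (Homo sapiens) for antiproliferative activity, read by MTT assay, with a stated time of 72 h (a lower number here means a stronger inhibitor, a higher number a weaker inhibitor), compound 1 `C/C=C/C(=O)Nc1cccc(Oc2nc(Nc3ccc(OC)nc3)nc3c2CSCC3)c1` gives 8040 nM and compound 2 `COc1ccc(Nc2nc3c(c(Oc4cccc(NC(=O)C=C(C)C)c4)n2)CSCC3)cn1` gives 16800 nM as the higher, weaker number of the two, a gap beyond the scatter. Compound 3 `COc1ccc(Nc2nc3c(c(Oc4cccc(NC(=O)/C=C/C(C)C)c4)n2)CSCC3)cn1` has not yet been measured. It differs from compound 2 in one place only, on a carbonyl carbon whose other neighbours are amide-type nitrogen, where 3-methylbut-1-en-1-yl stands in place of 2-methylprop-1-en-1-yl (3-methylbut-1-en-1-yl in place of 2-methylprop-1-en-1-yl on a carbonyl carbon) while the shared core stays the same. Among the compounds with values here, the only measured change at this place is the modest 2.1-fold higher number from compound 1 to compound 2 (0.32 log units; beyond the scatter) when 2-methylprop-1-en-1-yl replaces prop-1-en-1-yl. That single step sets no trend, and neither measured compound carries 3-methylbut-1-en-1-yl. In this assay a shift no larger than that modest step is therefore expected, with no firm direction and most likely nothing beyond the scatter. The expected change is a 1.1-fold lower number from compound 2 to compound 3 (0.05 log units; within the scatter) and it remains only an estimate. For compound 3 the estimated value is 15000 nM with an expected range from 6500 nM to 34000 nM in this measurement.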

Compound 3, half-maximal inhibitory concentration: 24200 nM
Beside the measured number, compound 3's estimate is 1.6-fold (0.21 log units) below it; low and high end bracket the measured number.
By their numbers in this assay, from the lowest: compound 1; then compounds 2 and 3 (each within the scatter of the next).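

In this assay, placing 3-methylbut-1-en-1-yl instead of 2-methylprop-1-en-1-yl on the carbonyl carbon gives a 1.4-fold higher number from compound 2 to compound 3 (0.16 log units; within the scatter), so this second exchange at the position leaves compound 2 and compound 3 within the scatter of each other, and these two groups are not told apart here. Set against prop-1-en-1-yl, the picture is clearer: isopropyl in place of methyl on a double-bonded chain carbon bound to a double-bonded chain carbon gives a 3.0-fold higher number from compound 1 to compound 3 (0.48 log units; beyond the scatter), and with its step to compound 2 also beyond the scatter, compound 1 stands as the strongest inhibitor of the three, with neither of the other two chains matching it. No evidence at hand bears on why the numbers fall this way.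

These three compounds leave open whether a shorter group on the carbonyl carbon, such as an unsubstituted ethenyl, would bring the number lower than that of compound 1. They also leave open what a saturated chain such as propyl, or a chain ending in a dimethylamino group, would do at this position.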